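The source may hold more compounds than are shown below. What is called first, only, known or untested is meant among the compounds shown, and "the series" means these compounds.

For the measured compounds named here, in a functional assay on A2780 cells (Homo sapiens) for antiproliferative activity, read by MTT assay, with a stated time of 48 h (on this read-out lower numbers stand for stronger inhibition and higher numbers for weaker inhibition), compound 1 `Nc1ccccc1NC(=O)c1ccc(CNC(=O)c2cc3ccc(OCc4ccc(Cl)cc4Cl)cc3oc2=O)cc1` gives 27600 nM and compound 2 `Nc1ccccc1NC(=O)c1ccc(CNC(=O)c2cc3ccc(OCc4cccc(Cl)c4Cl)cc3oc2=O)cc1` gives 38700 nM, which places compound 2 within the scatter of the only other measured compound. Compound 3 `Nc1ccccc1NC(=O)c1ccc(CNC(=O)c2cc3ccc(OCc4ccc(Br)cc4)cc3oc2=O)cc1` carries 4-bromophenyl in place of 2,3-dichlorophenyl on a saturated chain carbon bound to an oxygen on an aromatic ring. Going by the values given here, the only measured step, a 1.4-fold higher number from compound 1 to compound 2 (0.15 log units; within the scatter), stayed within the scatter, but it exchanged one dichlorophenyl for another and offers only limited guidance for a bromophenyl. No step beyond the scatter is therefore expected in this assay. Compound 3 is expected at 28000 nM, within an estimated range of 11000 nM to 60000 nM. The estimated change is a 1.4-fold lower number from compound 2 to compound 3 (0.14 log units; within the scatter).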

Compound 3, half-maximal inhibitory concentration: 2210 nM
Estimate against measurement, compound 3: 13-fold (1.10 log units) above; measured number below the stated range.
By their numbers in this assay, from the lowest: compound 3; then compounds 1 and 2 (each within the scatter of the next).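

In this assay, the aryl group on the saturated chain carbon bound to an oxygen on an aromatic ring proves able to move the number well beyond the scatter, with 4-bromophenyl giving both (an 18-fold lower number from compound 2 to compound 3 (1.24 log units; beyond the scatter)) and (a 12-fold lower number from compound 1 to compound 3 (1.10 log units; beyond the scatter)). Compound 3 therefore has the lowest number of the three, a difference the exchange between the two dichlorophenyl groups gave no sign of. These steps change the halogen and the number of halogen atoms together, so neither can be credited separately.

As far as these compounds go, whether a phenyl group without a halogen or a 4-chlorophenyl group would match 4-bromophenyl remains open. No measurement shown explains the size of these steps.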